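The source may report more compounds than this note shows. Statements on the series, on what has been measured and on what is new or still open speak of the compounds shown alone.

Among the compounds with values here, compound 1 `Cc1noc(NS(=O)(=O)c2cccc3ccccc23)c1C` gives the highest of the two numbers so far in an assay on thoracic aorta for binding affinity to Endothelin-1 receptor (Rattus norvegicus) (a lower number here means a stronger inhibitor, a higher number a weaker inhibitor), with 3100 nM; compound 2 `Cc1noc(NS(=O)(=O)c2cccc3cc(N(C)C)ccc23)c1C` gives 840 nM, and the only step yet known is a 3.7-fold lower number from compound 1 to compound 2 (0.57 log units; beyond the scatter). Compound 3 `Cc1noc(NS(=O)(=O)c2cccc3ccc(N)cc23)c1C` differs from compound 1 by amino in place of hydrogen on an aromatic carbon. That measured step also brings in a nitrogen group on the fused ring, though not the same group, so it bears only loosely on the change at hand. For compound 3 the expected step is therefore a smaller one, a 2.1-fold lower number from compound 1 to compound 3 (0.32 log units; beyond the scatter). Compound 3 is estimated at 1500 nM, with a range from 500 nM to 4500 nM.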

Compound 3, half-maximal inhibitory concentration: 1450 nM
Compound 3: middle estimate off by 1.0-fold (0.01 log units), on the high side, within the range that was stated.
By their numbers in this assay, from the lowest: compounds 2 and 3 (each within the scatter of the next); then compound 1.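

Amino in place of hydrogen on an aromatic carbon, meta to a fused ring and para to a fused ring, gives a 2.1-fold lower number from compound 1 to compound 3 (0.33 log units; beyond the scatter) in this assay and so shows that this position responds to the change. The smallest nitrogen group tried here is enough for a modest step beyond the scatter, so the lower number does not depend on the dimethylamino group of compound 2. No measurement here accounts for this step. On these data alone, whether dimethylamino at this same position would give a different number stays open. So does the effect of a methoxy group or a carboxylic acid there.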